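This account rests on a few compounds, and the source may have more. Where it says the series, first, only, none or still open, it means among the compounds named here.

Measured in a functional assay on HeLa cells (Homo sapiens) for inhibition, read by sulforhodamine B assay; a lower number here means a stronger inhibitor, a higher number a weaker inhibitor:
compound 1, `Cc1ccc(NC2=CC(=O)c3nc4n(c3C2=O)[C@H]2OC[C@@H](O)[C@H]2OC4)cc1C`, gives 2690 nM
compound 2, `Cc1ccc(NC2=CC(=O)c3c(nc4n3[C@H]3OC[C@@H](O)[C@H]3OC4)C2=O)cc1C`, gives 4320 nM
compound 3, `COc1cccc(NC2=CC(=O)c3nc4n(c3C2=O)[C@H]2OC[C@@H](O)[C@H]2OC4)c1`, gives 4280 nM

Compound 2 carries the largest of the three numbers, yet its gap to compound 3 and its gap to compound 1 both lie within the scatter, so the three compounds are not separated in this assay. Compound 4, `Cc1ccc(NC2=CC(=O)c3c(nc4n3[C@H]3OC[C@@H](O)[C@H]3OC4)C2=O)cc1`, is not yet measured. It differs from compound 2 by hydrogen in place of methyl on an aromatic carbon. For the measured compounds named here, the only measured step that changes the aryl group is a 1.6-fold higher number from compound 1 to compound 3 (0.20 log units; within the scatter); it shows no movement beyond the scatter, but it swaps a different pair of groups and sits on the core of compound 1 rather than that of compound 2, so it bears only loosely on the loss of a single methyl. Going by the values given here, no step of this exact kind exists. Compound 4 is therefore expected to remain within the scatter of compound 2, with an estimated step of a 1.0-fold higher number from compound 2 to compound 4 (0.02 log units; within the scatter). Compound 4 is estimated to give 4500 nM, in the expected range 2000 nM to 10000 nM.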

Compound 4, half-maximal inhibitory concentration: 6590 nM
For compound 4 the middle estimate is 1.5-fold (0.17 log units) below the measured one; the range from low to high includes it.
By their numbers in this assay, from the lowest: compounds 1, 3, 2 and 4 (each within the scatter of the next, the first and the last beyond it).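

Hydrogen in place of methyl on this aromatic carbon gives a 1.5-fold higher number from compound 2 to compound 4 (0.18 log units; within the scatter) in this assay on the core of compound 2. For the compounds shown here, this is the first step that isolates a single methyl here, rather than a swap of two different aryl groups, and it shows that 3,4-dimethylphenyl and 4-methylphenyl are not separated at this position. No measurement on hand offers an explanation for this result. Open, on these data alone, is whether an amine, a carboxylic acid or a longer chain on this carbon would move beyond the scatter. Also open, as far as these compounds go, is whether the same methyl loss reads alike on the core of compound 1.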